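A few compounds are considered here, and "the series" means these few. Any claim that something is new, unique, unknown or untested is made for them only; others in the source may bear on it.

In an assay on HEK293 cells for agonist activity at Bile acid receptor (Homo sapiens) (on this read-out higher numbers stand for an effect only at larger amounts of compound and lower numbers for an effect already at smaller amounts), compound 1 `O=C(O)c1ccc(C2CC2c2ccc(OCc3c(-c4c(Cl)cccc4Cl)noc3C3CC3)cc2Cl)cn1` gives 57 nM and holds the highest of the two numbers measured; its nearest neighbour, compound 2 `O=C(O)c1cccc([C@@H]2C[C@H]2c2ccc(OCc3c(-c4c(Cl)cccc4Cl)noc3C3CC3)cc2Cl)c1`, gives 29 nM, and a 2.0-fold lower number from compound 1 to compound 2 (0.29 log units; within the scatter). Compound 3 `Clc1cc(OCc2c(-c3c(Cl)cccc3Cl)noc2C2CC2)ccc1C1CC1c1ccc(-c2nnn[nH]2)nc1` differs from compound 1 in one place: 1H-tetrazol-5-yl in place of carboxy on an aromatic carbon. Among the compounds with values here, the single measured step exchanges the ring that bears the carboxy and leaves the carboxy itself in place, so no measured step speaks directly to this exchange. Given that gap, a step of a 1.2-fold higher number from compound 1 to compound 3 (0.09 log units; within the scatter) is expected, nothing beyond the scatter. Compound 3 is estimated at 70 nM, within a range from 20 nM to 250 nM.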

Compound 3, half-maximal effective concentration: 111 nM
Beside the measured number, compound 3's estimate is 1.6-fold (0.20 log units) below it; measured number inside the range.
By their numbers in this assay, from the lowest: compounds 2, 1 and 3 (each within the scatter of the next, the first and the last beyond it).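

At this position, on an aromatic carbon next to the ring nitrogen and para to a large group, the exchange of carboxy for 1H-tetrazol-5-yl can now be read directly in this assay: a 1.9-fold higher number from compound 1 to compound 3 (0.29 log units; within the scatter). The carboxy can therefore give way to this larger ring without a step beyond the scatter. From the compounds shown here alone, whether a primary amide or a sulfonamide on this carbon would read alike stays open, as does the same exchange on the 3-carboxyphenyl of compound 2. Nothing measured here explains why these two groups read alike.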